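This account rests on a few compounds, and the source may have more. Where it says the series, first, only, none or still open, it means among the compounds named here.

Compound 1 `[N-]=[N+]=NCc1ncnc2c1ncn2[C@@H]1O[C@H](CO)[C@@H](O)[C@H]1O`: > 250000 nM, a limit
Compound 2 `OC[C@H]1O[C@@H](n2cnc3c(Cn4ccc5ccccc54)ncnc32)[C@H](O)[C@@H]1O`: > 250000 nM, a limit

Both compounds were tested in a functional assay on Huh-7 cells (Homo sapiens) for cytotoxicity, read by MTT assay, with a stated time of 3 days; on this read-out higher numbers stand for lower toxicity in this test and lower numbers for higher toxicity in this test. Compound 2 gives no number there, only the limit > 250000 nM. Compound 1 also gives only a limit, > 250000 nM. Neither compound therefore offers a measured value from which to count a change.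

Compound 3 `O=c1ccn(Cc2ncnc3c2ncn3[C@@H]2O[C@H](CO)[C@@H](O)[C@H]2O)cc1` keeps the shared core of compound 2 and alters the substituent: a group of 7 heavy atoms (5 carbon, 1 nitrogen, 1 oxygen; one six-membered aromatic ring with 1 hetero atom) in place of a group of 9 heavy atoms (8 carbon, 1 nitrogen; one five-membered aromatic ring with 1 hetero atom, one six-membered aromatic ring of carbon only), on a saturated chain carbon bound to an aromatic carbon. Among the compounds with values here, one measured step bears on this change, as it concerns the same place on the saturated chain carbon bound to an aromatic carbon: a step that the two limits leave unreadable from compound 1 to compound 2. Its size cannot be read, so it offers no guide to magnitude.

Within the data shown here, the only other evidence is the limit of > 250000 nM in this assay, at which 2 of the 2 values shown sit. On that basis, no step beyond the usual scatter is expected in this assay, in either direction, though a limit could conceal one. The expected size is a number no higher from compound 2 to compound 3 (the limit leaves the size open), which is an estimate. The estimate for compound 3 is 250000 nM, with an expected range of 100000 nM to 500000 nM.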

Compound 3, half-maximal cytotoxic concentration: > 100000 nM
Compound 3 gave a limit, no number (the forecaster's own chance of this, stated with the estimate: 85%); the middle value lies beyond the limit too.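

Within the data shown here, compound 1, compound 2 and compound 3 each give only a limit in this assay, so no step among them can be read. The compounds shown leave open whether azido, 1H-indol-1-yl or the group in compound 3, on a saturated chain carbon bound to an aromatic carbon, changes the read-out at all.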